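Compound 3 to compound 4: a step at the limit

A few compounds are considered here, and "the series" means these few. Any claim that something is new, unique, unknown or untested is made for them only; others in the source may bear on it.

Of the compounds shown here, three have been read so far in an ADME assay on HepG2 cells (Homo sapiens) for cytotoxicity, in the presence of a further agent that is not named here (a lower number here means a stronger inhibitor, a higher number a weaker inhibitor), and none has given a number. Compound 1 (`O=C(NCc1ccccc1)c1nc(Cc2ccccc2C(F)(F)F)[nH]c(=O)c1O`) gives > 100000 nM as a limit of the assay. Compound 2 (`Cn1c(Cc2ccccc2)nc(C(=O)NCc2ccccc2)c(O)c1=O`) gives > 100000 nM as a limit too. Compound 3 (`Cn1c(Cc2ccccc2C(F)(F)F)nc(C(=O)NCC2CCCCC2)c(O)c1=O`) gives > 100000 nM as a limit as well. Compound 3 thus has no rank of its own, and the whole picture is the limit of > 100000 nM in this assay, at which 3 of the 3 values shown sit, and nothing finer.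

Compound 4 (`Cn1c(Cc2ccccc2C(F)(F)F)nc(C(=O)CCc2ccccc2)c(O)c1=O`) has phenethyl in place of (cyclohexylmethyl)amino on a carbonyl carbon, so that (cyclohexylmethyl)carbamoyl becomes phenethylcarbonyl. Among the measured compounds shown here, no step between measured compounds is available to size this change. The three readings give no sign of any structural trend in this assay and no direction can be drawn from them. No shift beyond the scatter is therefore expected. The expected change is a number no higher from compound 3 to compound 4 (the limit leaves the size open) as an estimate only. A limit reading is the most likely outcome for the next measurement. The estimated value for compound 4 is 100000 nM with an expected range of 40000 nM to 200000 nM in this assay as the read-out.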

Compound 4, half-maximal inhibitory concentration: > 100000 nM
Compound 4 was reported as a limit; the forecaster's own chance of this, stated with the estimate: 85%; the middle value lies on the limit itself.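

In this assay compound 4 gives > 100000 nM, a limit of the assay. Among the compounds shown here, compound 3 gives > 100000 nM, also a limit, so no step from compound 3 to compound 4 can be read. The series still shows a single reading: the limit of > 100000 nM in this assay, at which 4 of the 4 values shown sit.

Going by these compounds, whether any structural change gives a measured number in this assay remains open.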